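Methyl on the Saturated Ring: a Small Step Repeated

The compounds below may be only part of what the source reports. "The series", "measured", "known", "first", "only" and "open" are said of these compounds alone.

Compound 1 `O=C1NCCN(c2cccc(Cl)c2)N1` and compound 2 `CC1CN(c2cccc(Cl)c2)NC(=O)N1` share a core that bears a chlorophenyl group; compound 3 `O=C1NCCN(c2cccc(Cl)n2)N1` and compound 4 `CC1CN(c2cccc(Cl)n2)NC(=O)N1` carry a chloropyridyl group instead, and the difference between the two cores is not broken down here. In a functional assay on cells for inhibition of Polyunsaturated fatty acid 5-lipoxygenase (Homo sapiens) (a lower number here means a stronger inhibitor, a higher number a weaker inhibitor), compound 1 gives 2100 nM, and compound 2 gives 2700 nM; the change between them is methyl in place of hydrogen on a saturated ring carbon, and the step is a 1.3-fold higher number from compound 1 to compound 2 (0.11 log units; within the scatter). In this assay compound 3 gives 4800 nM, a higher number than compound 1 by more than the usual scatter, while its gap to compound 2 lies within the scatter.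

Within the data shown here, compound 4 differs from compound 3 by methyl in place of hydrogen on a saturated ring carbon, the same change in the same place as the one from compound 1 to compound 2. Because the step of a 1.3-fold higher number from compound 1 to compound 2 (0.11 log units; within the scatter) hardly moved the number, a similarly small step is expected here, a 1.3-fold higher number from compound 3 to compound 4 (0.10 log units; within the scatter). In this assay compound 4 is therefore estimated at 6000 nM, with a likely range from 3000 nM to 12000 nM.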

Compound 4, half-maximal inhibitory concentration: 1600 nM
Beside the measured number, compound 4's estimate is 3.8-fold (0.57 log units) above it, outside the stated range (below it).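

In this assay, placing a methyl on the saturated ring carbon of the core bearing the chloropyridyl group gives a 3.0-fold lower number from compound 3 to compound 4 (0.48 log units; beyond the scatter), a real if modest gain in inhibition, whereas the same change on the core bearing the chlorophenyl group left the number within the scatter. The effect of this methyl therefore does not carry over unchanged from one core to the other: the same change on two cores in this assay, a 1.3-fold higher number (0.11 log units; within the scatter) from compound 1 to compound 2 and a 3.0-fold lower number (0.48 log units; beyond the scatter) from compound 3 to compound 4, 3.9-fold (0.59 log units) apart, beyond the scatter of two such steps. This shows that, for these two pairs, the outcome of the change depends on the core it is made on, but it does not show why, and one pair on each core gives no general rule.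

Going by these compounds, it remains open whether a longer chain such as ethyl, or a hydroxymethyl group, on the same saturated ring carbon would follow the methyl on either core. Also open, on these data alone, is whether a third core would behave like the chlorophenyl pair or the chloropyridyl pair.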